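This account rests on a few compounds, and the source may have more. Where it says the series, first, only, none or still open, it means among the compounds named here.

Working notes on the series. In a functional assay on KB 3-1 cells (Homo sapiens) for cytotoxicity, read by MTT assay, with a stated time of 72 h (a lower number here means a stronger inhibitor, a higher number a weaker inhibitor), compound 1 `O=C1Nc2ccccc2/C1=N/NC(=S)Nc1ccc(Cl)cc1` gives 13400 nM and compound 2 `CN(C)c1ccc(NC(=S)N/N=C2\C(=O)Nc3ccccc32)cc1` gives 6950 nM. Within the data shown here, these two values lie within the scatter of each other, so compound 2 stands level with the only other measured compound.

The next change leads to compound 3 `O=C1Nc2ccccc2/C1=N/NC(=S)Nc1ccc(C(F)(F)F)cc1`: trifluoromethyl in place of dimethylamino on an aromatic carbon. In words, this is trifluoromethyl in place of dimethylamino on an aromatic carbon.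

Among the measured compounds shown here, one measured step bears on it: a 1.9-fold lower number from compound 1 to compound 2 (0.29 log units; within the scatter), with dimethylamino in place of chloro on an aromatic carbon. For the measured compounds named here, that single step stayed within the scatter, and no measured compound yet carries trifluoromethyl. No step beyond the scatter is therefore expected in this assay, with a slightly higher number as the likelier direction.

The expected step is a 1.4-fold higher number from compound 2 to compound 3 (0.16 log units; within the scatter). For compound 3 the estimated value is 10000 nM, with an expected range of 4000 nM to 25000 nM.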

Compound 3, half-maximal inhibitory concentration: 8590 nM
Compound 3: the middle estimate sits 1.2-fold (0.07 log units) above what was measured, and the stated range covers the measured number.
By their numbers in this assay, from the lowest: compounds 2, 3 and 1 (each within the scatter of the next).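

In this assay the position on the aromatic ring, para to a large group, has now carried chloro, dimethylamino and trifluoromethyl, and all three compounds remain within the scatter of one another (a 1.2-fold higher number from compound 2 to compound 3 (0.09 log units; within the scatter); a 1.6-fold lower number from compound 1 to compound 3 (0.19 log units; within the scatter)). Trifluoromethyl, with no hydrogen-bond acceptor, stands level with dimethylamino, which has one, so among these compounds that count shows no link to the readout. No measured evidence bears on why these groups stand level.

The compounds shown leave open whether a group of another kind at this position, such as a carboxylic acid or a primary amine, would give a step beyond the scatter. They also leave open whether a change to the shared core, away from this position, would do so.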